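Replacing bromo with methoxycarbonyl on compound 1

The source may report more compounds than this note shows. Statements on the series, on what has been measured and on what is new or still open speak of the compounds shown alone.

Compound 1 `C=CC(=O)N1C(=O)CC(c2ccc(Br)cc2)Sc2ccccc21`: 51300 nM
Compound 2 `C=CC(=O)N1C(=O)CC(c2cccs2)Sc2ccccc21`: 659000 nM

Both values come from a functional assay on Raji cells (Homo sapiens) for cytotoxicity, read by CCK-8 assay, with a stated time of 24 h; on this read-out higher numbers stand for weaker inhibition and lower numbers for stronger inhibition. Compound 1 holds the lower of the two numbers, so it is the stronger inhibitor of this pair. Compound 3 `C=CC(=O)N1C(=O)CC(c2ccc(C(=O)OC)cc2)Sc2ccccc21` has not yet been measured. It keeps the core of compound 1 and changes a single group: methoxycarbonyl in place of bromo on an aromatic carbon. In words, methoxycarbonyl stands in place of bromo on an aromatic carbon, para to a large group.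

For the measured compounds named here, only one measured step bears on this change, and only loosely. Putting thiophen-2-yl in place of 4-bromophenyl gave a 13-fold higher number from compound 1 to compound 2 (1.11 log units; beyond the scatter), a large step. That swap replaced the whole aromatic group, whereas compound 3 changes only the bromo on it, so a smaller step is expected. Going by the values given here, the direction is uncertain, but the sole measured departure from compound 1 raised the number, so a slight rise is the cautious expectation, possibly no larger than the scatter. The expected step is a 1.9-fold higher number from compound 1 to compound 3 (0.29 log units; within the scatter). For compound 3 the estimated value is 100000 nM, with an expected range from 30000 nM to 350000 nM.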

Compound 3, half-maximal inhibitory concentration: 89600 nM
Compound 3: the middle estimate sits 1.1-fold (0.05 log units) above what was measured; the range from low to high includes it.
By their numbers in this assay, from the lowest: compounds 1 and 3 (each within the scatter of the next); then compound 2.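

In this assay, methoxycarbonyl in place of bromo gives a 1.7-fold higher number from compound 1 to compound 3 (0.24 log units; within the scatter), so the two groups cannot be told apart at this aromatic carbon, even though the entering group is larger by heavy-atom count and brings a double bond and hydrogen-bond acceptors that bromo lacks. The earlier pair showed only that exchanging the entire aromatic group can move the number a long way, with a 13-fold higher number from compound 1 to compound 2 (1.11 log units; beyond the scatter); this result shows that a change confined to the group para to a large group, with the six-membered aromatic ring kept, need not do the same. Nothing available explains why the two groups read alike in these cells.

The compounds shown leave open whether the number would also hold with an amine, a carboxylic acid or a longer alkyl chain on this same carbon, any of which would test how broad the range of accepted groups is. They also leave open what a plain hydrogen would give there, which would show whether this carbon needs a substituent at all.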